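Replacing an Acetate with a Free Hydroxyl on the Side Chain

This account rests on a few compounds, and the source may have more. Where it says the series, first, only, none or still open, it means among the compounds named here.

Measured so far in a functional assay on HCT-116 cells (Homo sapiens) for inhibition, read by fluorescence, with a stated time of 48 h; a higher number here means a weaker inhibitor of growth, a lower number a stronger inhibitor of growth:
compound 1 `CC(C)[C@H](N)C(=O)OCCCOC1(c2ccc(Cl)cc2)c2ccccc2C(=O)N1Cc1ccccc1` gives 20000 nM
compound 2 `CC(=O)OCC(C)(C)COC1(c2ccc(Cl)cc2)c2ccccc2C(=O)N1Cc1ccc(Cl)cc1` gives 35000 nM
compound 3 `O=C1c2ccccc2C(OCCCO)(c2ccc(Cl)cc2)N1Cc1ccccc1` gives 79000 nM

Among these three, compound 2 sits within the scatter of compound 1 and clearly lower than compound 3, which carries the highest number of the set. Compound 4 `CC(C)(CO)COC1(c2ccc(Cl)cc2)c2ccccc2C(=O)N1Cc1ccc(Cl)cc1` has not yet been measured. It differs from compound 2 by hydrogen in place of acetyl on an oxygen on a saturated carbon. For the measured compounds named here, the only measured step that bears on this change is the one from compound 1 to compound 3, where a free hydroxyl also replaced an ester on the same side-chain oxygen: a 4.0-fold higher number from compound 1 to compound 3 (0.60 log units; beyond the scatter). That step ran toward a weaker inhibitor, and the change here is of the same kind, so a rise of similar size in this assay is expected for compound 4, though the leaving group is smaller and the exact size is uncertain. The author therefore expects a 2.0-fold higher number from compound 2 to compound 4 (0.30 log units; within the scatter), giving compound 4 an estimated 70000 nM, with a range from 30000 nM to 160000 nM.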

Compound 4, concentration for 50% growth inhibition: 50000 nM
The estimate for compound 4 lay 1.4-fold (0.15 log units) above the measured number, within the range that was stated.
By their numbers in this assay, from the lowest: compounds 1, 2, 4 and 3 (each within the scatter of the next, the first and the last beyond it).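

In this assay, hydrogen in place of acetyl on an oxygen on a saturated carbon gives a 1.4-fold higher number from compound 2 to compound 4 (0.15 log units; within the scatter) and so does not separate the acetoxymethyl from the hydroxymethyl compound. The earlier step of the same kind, a 4.0-fold higher number from compound 1 to compound 3 (0.60 log units; beyond the scatter) and printed as beyond the scatter, therefore does not carry over as a single outcome for this change; those two pairs differ both in the group that leaves and in the rest of the molecule. No measurement shown here gives a reason for the contrast between the two steps.

The compounds shown leave open whether a methyl ether or a carboxylic acid at this position would read apart from the acetate and the hydroxyl. They also leave open how the amino ester of compound 1 would behave on the side chain of compound 4.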